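This account rests on a few compounds, and the source may have more. Where it says the series, first, only, none or still open, it means among the compounds named here.

Compound 1 `CNC(=O)c1cc(Oc2ccc3nc(Nc4ccccc4)ncc3c2)ccn1`: in a physicochemical assay for solubility, at pH 7 (on this read-out higher numbers stand for higher solubility and lower numbers for lower solubility), compound 1 gives < 1000 nM, a limit of the assay.
Compound 2 `CNC(=O)c1cc(Oc2ccc3nc(Nc4cccc(C(C)(C)C)c4)ncc3c2)ccn1`: compound 2 gives < 1000 nM, again a limit.
Compound 3 `CCc1ccccc1Nc1ncc2cc(Oc3ccnc(C(=O)NC)c3)ccc2n1`: compound 3 gives < 1000 nM, also a limit.

Compound 3 therefore stands only at a limit, not at a number, and all three values sit at the limit of < 1000 nM in this assay, at which 3 of the 3 values shown sit. Compound 4 `CNC(=O)c1cc(Oc2ccc3nc(Nc4cccc(Cl)c4)ncc3c2)ccn1` differs from compound 3 in one place: 3-chlorophenyl in place of 2-ethylphenyl on a nitrogen on an aromatic ring. The steps a step that the two limits leave unreadable from compound 2 to compound 3 and a step that the two limits leave unreadable from compound 1 to compound 3 bear on this change, but both are unreadable between limits, so no size or direction can be taken from them. Compound 4 is expected to stay at the limit as well, with an expected step that the limit leaves unreadable from compound 3 to compound 4, and its estimated value is 400 nM, within 80 nM to 2000 nM.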

Compound 4, solubility: < 1000 nM
Compound 4: only a limit was reported; the forecaster's own chance of this, stated with the estimate: 85%; the middle value is on the limit's open side.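

Compound 4, like compound 1, compound 2 and compound 3, gives only a limit in this assay, so no step among them can be read: the limit of < 1000 nM in this assay, at which 4 of the 4 values shown sit.

Going by these compounds, what stays open is where each compound's true value lies, and whether the changes of group on the nitrogen make any difference.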